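This account rests on a few compounds, and the source may have more. Where it says the series, first, only, none or still open, it means among the compounds named here.

The measured compounds:
compound 1, `O=C(Nc1cccc(-c2oc3cc(-c4ccc(F)cc4)ccc3c(=O)c2O)c1)c1ccc(F)cc1`: 8590 nM
compound 2, `COc1cc(OC)cc(C(=O)Nc2cccc(-c3oc4cc(-c5ccc(F)cc5)ccc4c(=O)c3O)c2)c1`: 3470 nM
compound 3, `Cc1cc(C)cc(C(=O)Nc2cccc(-c3oc4cc(-c5ccc(F)cc5)ccc4c(=O)c3O)c2)c1`: 20400 nM

All three were tested in a functional assay on MCF7 cells (Homo sapiens) for antiproliferative activity, read by CCK-8 assay, with a stated time of 72 h; on this read-out lower numbers stand for stronger inhibition and higher numbers for weaker inhibition. Compound 3 gives the highest number of the three and is the least active on this read-out: both a 2.4-fold higher number from compound 1 to compound 3 (0.38 log units; beyond the scatter) and a 5.9-fold higher number from compound 2 to compound 3 (0.77 log units; beyond the scatter) run upward and lie beyond the scatter. Compound 2 stands lowest, reached by a 2.5-fold lower number from compound 1 to compound 2 (0.39 log units; beyond the scatter).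

Compound 4, `CCCc1ccc(C(=O)Nc2cccc(-c3oc4cc(-c5ccc(F)cc5)ccc4c(=O)c3O)c2)cc1`, is not yet measured in this assay. It differs from compound 3 by 4-propylphenyl in place of 3,5-dimethylphenyl on a carbonyl carbon. Two measured steps end at compound 3 and bear on this part of the molecule: the step from compound 1 and the step from compound 2, each a modest rise. Neither involves a 4-propylphenyl, so the direction of the new step is not fixed by the data; the nearest comparison is compound 1, which carries a single substituent on this ring and gives 8590 nM in this assay. On that basis compound 4 is expected to show a modest fall in the number, a 1.7-fold lower number from compound 3 to compound 4 (0.23 log units; within the scatter). Compound 4 is estimated at 12000 nM, with a range from 4000 nM to 35000 nM.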

Compound 4, half-maximal inhibitory concentration: 36800 nM
The estimate for compound 4 lay 3.1-fold (0.49 log units) below the measured number; the whole stated range lies below it.
By their numbers in this assay, from the lowest: compound 2; then compound 1; then compounds 3 and 4 (each within the scatter of the next).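

In this assay, the 4-propylphenyl on the carbonyl carbon does not separate from the 3,5-dimethylphenyl, with a 1.8-fold higher number from compound 3 to compound 4 (0.26 log units; within the scatter), so compounds 3 and 4 sit together at the weak end of the set despite their different substitution on this ring. A single substituent on the ring therefore does not by itself keep the number close to that of compound 1: with propyl in place of fluoro on an aromatic carbon, the result is a 4.3-fold higher number from compound 1 to compound 4 (0.63 log units; beyond the scatter). For the compounds shown here, the change at this position now spans an 11-fold higher number from compound 2 to compound 4 (1.03 log units; beyond the scatter), the only step here graded as large, and this leaves the 3,5-dimethoxyphenyl of compound 2 lowest of the four.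

No measurement shown bears on the reason for these differences. From the compounds shown here alone, it remains open whether a ring carrying a single methoxy, an ethyl group, a longer chain such as butyl, an amine or a carboxylic acid would fall nearer compound 2 or nearer compound 4.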